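This account rests on a few compounds, and the source may have more. Where it says the series, first, only, none or still open, it means among the compounds named here.

Three compounds share one core: an amide of a hydroxy acid that carries a trifluoromethyl group, joined to an aniline whose ring bears a sulfonyl link to a second aromatic ring. In a functional assay (Cavia porcellus) with sulfonylurea receptors; K-ATP channels (Homo sapiens) as the target (on this read-out higher numbers stand for weaker inhibition and lower numbers for stronger inhibition), compound 1 `CC(O)(C(=O)Nc1ccc(S(=O)(=O)c2ccccc2)c(F)c1)C(F)(F)F` gives 1800 nM, and compound 2 `CC(O)(C(=O)Nc1ccc(S(=O)(=O)c2ccc(F)cc2)cc1)C(F)(F)F` gives 8600 nM. Compound 3 `CC(O)(C(=O)Nc1ccc(S(=O)(=O)c2ccc(C#N)cc2)cc1)C(F)(F)F` gives only a limit of this assay, > 30000 nM, as the limit of > 30000 nM in this assay, at which 1 of the 3 values shown sits, records. Among the measured compounds shown here, the one measured step, an at least 3.4-fold higher number from compound 2 to compound 3 (0.54 log units; beyond the scatter), came with the nitrile entering. For the measured compounds named here, the change to compound 4 `COc1cccc(S(=O)(=O)c2ccc(NC(=O)C(C)(O)C(F)(F)F)cc2)c1`, namely (3-methoxyphenyl in place of 4-cyanophenyl on a sulfonyl sulfur), removes that nitrile again, so the number is expected to return toward compound 2 at 8600 nM, although a methoxy group appears in no measured compound. Compound 4 is therefore estimated at 10000 nM, between 3000 nM and 30000 nM. The expected step is an at least 3.0-fold lower number from compound 3 to compound 4 (0.47 log units; beyond the scatter).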

Compound 4, half-maximal inhibitory concentration: 16000 nM
The estimate for compound 4 lay 1.6-fold (0.20 log units) below the measured number, and the stated range covers the measured number.
By their numbers in this assay, from the lowest: compound 1; then compounds 2 and 4 (each within the scatter of the next). At a limit, above all of these: compound 3.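

On the sulfonyl sulfur, 3-methoxyphenyl and 4-fluorophenyl cannot be told apart by this read-out: a 1.9-fold higher number from compound 2 to compound 4 (0.27 log units; within the scatter). Against the nitrile, the change gives an at least 1.8-fold lower number from compound 3 to compound 4 (0.27 log units; that floor lies within the scatter), so the size of any recovery on losing the nitrile remains unknown. Compound 3 stands at a limit, not at a number: the limit of > 30000 nM in this assay, at which 1 of the 4 values shown sits.

As far as these compounds go, what an amine or a carboxylic acid on this aromatic ring would do to the number stays open. The compounds shown also do not separate the effect of the methoxy group from the effect of where it sits.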